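The source may report more compounds than this note shows. Statements on the series, on what has been measured and on what is new or still open speak of the compounds shown alone.

Of the compounds shown here, three sharing one core have so far been measured in a functional assay on HL-60 cells (Homo sapiens) for cytotoxicity, read by WST assay, with a stated time of 48 h; a lower number here means a stronger inhibitor, a higher number a weaker inhibitor. Compound 1 `COC[C@@H](C(C)C)C(c1ccc(O)c(OC)c1)c1ccc(O)c(OC)c1` gives 54000 nM. Compound 2 `CCCCC[C@H](C(C)C)C(c1ccc(O)c(OC)c1)c1ccc(O)c(OC)c1` gives 9600 nM, the lowest of the two plain numbers; its nearest neighbour is compound 1, reached by the step of a 5.6-fold lower number from compound 1 to compound 2 (0.75 log units; beyond the scatter). For compound 3 `COc1cc(C(c2ccc(O)c(OC)c2)[C@@H](C)[C@@H](C)CO)ccc1O` the assay reports only a limit, > 100000 nM, not a number. The steps of an at least 1.8-fold higher number from compound 1 to compound 3 (0.26 log units; that floor lies within the scatter) and an at least 10-fold higher number from compound 2 to compound 3 (1.01 log units; beyond the scatter) run toward that limit.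

Compound 4 `CC[C@H](C(C)C)C(c1ccc(O)c(OC)c1)c1ccc(O)c(OC)c1` is the next compound, and it differs from compound 2 by hydrogen in place of propyl on a saturated chain carbon, four bonds along the chain from two aromatic carbons. Among the measured compounds shown here, the one measured step that bears on it is a 5.6-fold lower number from compound 1 to compound 2 (0.75 log units; beyond the scatter), where 1-isopropylhexyl in place of 1-(methoxymethyl)-2-methylpropyl lowered the number by a modest amount. Shortening that same chain in compound 4 is expected to move the number back the other way, by a modest step of a 2.6-fold higher number from compound 2 to compound 4 (0.42 log units; beyond the scatter). Compound 4 is therefore estimated to give 25000 nM, with a likely range from 10000 nM to 70000 nM.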

Compound 4, half-maximal inhibitory concentration: 16000 nM
Beside the measured number, compound 4's estimate is 1.6-fold (0.19 log units) above it, within the range that was stated.
By their numbers in this assay, from the lowest: compounds 2 and 4 (each within the scatter of the next); then compound 1. At a limit, above all of these: compound 3.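

Going from 1-isopropylhexyl to 1-isopropylpropyl makes no readable difference in this assay (a 1.7-fold higher number from compound 2 to compound 4 (0.22 log units; within the scatter)), so at this place, four bonds along the chain from two aromatic carbons, the propyl can go without a change that stands out from the scatter. The gap from compound 1 therefore does not depend on the long chain, since the short 1-isopropylpropyl also keeps clear of the 1-(methoxymethyl)-2-methylpropyl of compound 1 (a 3.4-fold lower number from compound 1 to compound 4 (0.53 log units; beyond the scatter)). The step from compound 3 is also clear (an at least 6.2-fold lower number from compound 3 to compound 4 (0.79 log units; beyond the scatter)), although compound 3 gives a limit and not a number: the limit of > 100000 nM in this assay, at which 1 of the 4 values shown sits.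

From the compounds shown here alone, it remains open whether a chain longer than the pentyl of compound 2 would lower the number further. Going by these compounds, it also remains open how an amine or a carboxylic acid at the chain end would read.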